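This account rests on a few compounds, and the source may have more. Where it says the series, first, only, none or still open, it means among the compounds named here.

For the measured compounds named here, compound 1 `COC(CCNC(=O)Nc1cc2c(Nc3ccc(F)c(Cl)c3)ncnc2cc1O[C@H]1CCOC1)OC` is the weaker of the two measured members: in a functional assay on A-431 cells (Homo sapiens) for antiproliferative activity, read by sulforhodamine B assay, with a stated time of 72 h (on this read-out lower numbers stand for stronger inhibition and higher numbers for weaker inhibition), compound 1 gives 22000 nM, the highest of the two numbers recorded. Going by the values given here, its nearest measured neighbour is compound 2 `CN1CCN(C(=O)Nc2cc3c(Nc4ccc(F)c(Cl)c4)ncnc3cc2O[C@H]2CCOC2)CC1`, which in this assay gives 675 nM; the single change between them, 4-methylpiperazin-1-yl in place of (3,3-dimethoxypropyl)amino on a carbonyl carbon, brings a 33-fold lower number from compound 1 to compound 2 (1.51 log units; beyond the scatter).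

Compound 3 `O=C(Nc1cc2c(Nc3ccc(F)c(Cl)c3)ncnc2cc1O[C@H]1CCOC1)N1CCC(CCO)CC1` is not yet measured. It differs from compound 1 by 4-(2-hydroxyethyl)piperidin-1-yl in place of (3,3-dimethoxypropyl)amino on a carbonyl carbon. Among the compounds with values here, the change is the same kind of replacement as the one from compound 1 to compound 2: the (3,3-dimethoxypropyl)amino group leaves the carbonyl carbon and a group containing one six-membered non-aromatic ring with 1 hetero atom enters in its place. That step was large and lies beyond the scatter, so a lower number is expected for compound 3 as well, though the entering group here is 4-(2-hydroxyethyl)piperidin-1-yl rather than 4-methylpiperazin-1-yl and the size of the step carries less certainty. Compound 3 is therefore estimated at 1500 nM, with a range of 400 nM to 6000 nM, which means an expected step of a 15-fold lower number from compound 1 to compound 3 (1.17 log units; beyond the scatter).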

Compound 3, half-maximal inhibitory concentration: 759 nM
Beside the measured number, compound 3's estimate is 2.0-fold (0.30 log units) above it; the measured number falls inside the stated range.
By their numbers in this assay, from the lowest: compounds 2 and 3 (each within the scatter of the next); then compound 1.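

In this assay the large step is not confined to one entering group: a 29-fold lower number from compound 1 to compound 3 (1.46 log units; beyond the scatter) is a second large step on the same carbonyl carbon, here with 4-(2-hydroxyethyl)piperidin-1-yl as the group that replaces (3,3-dimethoxypropyl)amino. For the compounds shown here, the two ring-bearing groups cannot be told apart at this position, since a 1.1-fold higher number from compound 2 to compound 3 (0.05 log units; within the scatter) is printed as within the scatter, so across these three compounds neither the 4-methylpiperazin-1-yl group nor the terminal hydroxyl of the 2-hydroxyethyl chain is needed to reach this level, and no compound here goes against the lower numbers for the two ring-bearing groups. No measurement at hand explains the size of either step or the closeness of compound 2 and compound 3.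

Still open, going by these compounds, is whether the six-membered ring itself matters or whether the loss of the 3,3-dimethoxypropyl chain is enough, a question that an open-chain group such as dimethylamino or a simple 3-hydroxypropylamino on the same carbonyl carbon would address. Also open, on these data alone, is how far the piperidine substituent can vary, for example with a shorter hydroxymethyl chain, a primary amine or a carboxylic acid in place of the 2-hydroxyethyl group.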